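A few compounds are considered here, and "the series" means these few. Any claim that something is new, unique, unknown or untested is made for them only; others in the source may bear on it.

Compound 1 `CC(C)=CCc1cc(C(=O)Nc2cc3ccc(OCCC4CCCCN4)c(C)c3oc2=O)ccc1O` holds the lowest of the two numbers shown in a functional assay on SK-BR-3 cells (Homo sapiens) for antiproliferative activity; a lower number here means a stronger inhibitor, a higher number a weaker inhibitor: compound 1 gives 640 nM. The nearest is compound 3 `CCN(CC)CCCOc1ccc2cc(NC(=O)c3ccc(O)c(CC=C(C)C)c3)c(=O)oc2c1C`, which in this assay gives 4900 nM. Compound 2 `CC(C)=CCc1cc(C(=O)Nc2cc3ccc(OCCCN4CCCCC4)c(C)c3oc2=O)ccc1O` is reported in this assay only as a limit, > 50000 nM (the limit of > 50000 nM in this assay, at which 1 of the 3 values shown sits). Compound 4 `CC(C)=CCc1cc(C(=O)Nc2cc3ccc(OCCCNC(C)(C)C)c(C)c3oc2=O)ccc1O` differs from compound 1 in one place: ((tert-butyl)amino)methyl in place of piperidin-2-yl on a saturated chain carbon, two bonds along the chain from an oxygen on an aromatic ring. Both measured steps away from compound 1 replace that same group and weaken the compound, namely an at least 78-fold higher number from compound 1 to compound 2 (1.89 log units; beyond the scatter) and a 7.7-fold higher number from compound 1 to compound 3 (0.88 log units; beyond the scatter). Since the entering group of compound 4, unlike those of compound 2 and compound 3, still carries a hydrogen-bond donor as counted in the difference, a smaller weakening is expected, a 2.3-fold higher number from compound 1 to compound 4 (0.37 log units; beyond the scatter). Compound 4 is thus estimated to give 1500 nM in this assay, between 400 nM and 6000 nM.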

Compound 4, half-maximal inhibitory concentration: 660 nM
Compound 4: the middle estimate sits 2.3-fold (0.36 log units) above what was measured; low and high end bracket the measured number.
By their numbers in this assay, from the lowest: compounds 1 and 4 (each within the scatter of the next); then compound 3. At a limit, above all of these: compound 2.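

Opening the ring changes nothing measurable at this position: in this assay, the ((tert-butyl)amino)methyl group of compound 4 stands level with the piperidin-2-yl group of compound 1 (a 1.0-fold higher number from compound 1 to compound 4 (0.01 log units; within the scatter)). On the same chain, (tert-butyl)amino gives a stronger inhibitor than diethylamino (a 7.4-fold lower number from compound 3 to compound 4 (0.87 log units; beyond the scatter)) and than piperidin-1-yl (an at least 75-fold lower number from compound 2 to compound 4 (1.87 log units; beyond the scatter)), so the two groups that keep a hydrogen-bond donor, in compound 1 and compound 4, lead these four compounds. Compound 2 is reported only as a limit of the assay, not a number. Left open is whether a primary amine or a smaller secondary amine such as methylamino would hold this level on the same chain.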